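The source may hold more compounds than are shown below. What is called first, only, known or untested is meant among the compounds shown, and "the series" means these compounds.

Working notes on the shared core `Cc1ccc(NC(=O)N[C@H]2CC[C@H](Oc3ccc(F)cc3)CC2)cc1`, compound 3, in a functional assay on CRL2813 cells (Homo sapiens) for cytotoxicity, read by sulforhodamine B assay, with a stated time of 5 days; on this read-out higher numbers stand for weaker inhibition and lower numbers for stronger inhibition. Compound 3 gives only a limit of the assay, > 20000 nM; it sits at the limit of > 20000 nM in this assay, at which 1 of the 3 values shown sits. Compound 1 `COC(=O)c1ccc(NC(=O)N[C@H]2CC[C@H](Oc3ccc(F)cc3)CC2)cc1` gives 11600 nM and compound 2 `O=C(Nc1cccc([N+](=O)[O-])c1)N[C@H]1CC[C@H](Oc2ccc(F)cc2)CC1` gives 6700 nM. The steps to compound 3 ran an at least 1.7-fold higher number from compound 1 to compound 3 (0.23 log units; that floor lies within the scatter) and an at least 2.9-fold higher number from compound 2 to compound 3 (0.47 log units; beyond the scatter). Compound 4 `CSc1ccccc1NC(=O)N[C@H]1CC[C@H](Oc2ccc(F)cc2)CC1` differs from compound 3 by 2-(methylsulfanyl)phenyl in place of 4-methylphenyl on an amide-type nitrogen. Among the measured compounds shown here, only the step from compound 2 to compound 3, also an exchange of the aryl group on the amide-type nitrogen, bears on this change, and it points to a phenyl with a polar substituent giving a lower number than the 4-methylphenyl. Compound 4 is therefore expected at 15000 nM (range 5000 nM to 40000 nM), an estimated step of an at least 1.3-fold lower number from compound 3 to compound 4 (0.12 log units; that floor lies within the scatter), with a fair chance that only a limit is again returned.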

Compound 4, half-maximal inhibitory concentration: > 20000 nM
Compound 4: only a limit was reported; the forecaster's own chance of this, stated with the estimate: 40%; at least 1.3-fold (0.12 log units) between middle value and limit.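

In this assay compound 4 also returns only a limit of the assay, > 20000 nM, so the step from compound 3 cannot be read, and the 2-(methylsulfanyl)phenyl, despite its sulfur and its hydrogen-bond acceptor, gives no readable value at this amide-type nitrogen. Exchanging the 3-nitrophenyl for this group gives an at least 2.9-fold higher number from compound 2 to compound 4 (0.47 log units; beyond the scatter). Readable values at this place thus remain with compound 1 and compound 2, and compound 3 and compound 4 both sit at the limit: the limit of > 20000 nM in this assay, at which 2 of the 4 values shown sit.

Going by these compounds, what a phenyl carrying an amine, a carboxylic acid or a methylsulfonyl group would give at this nitrogen stays open.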